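The source may hold more compounds than are shown below. What is called first, only, known or untested is meant among the compounds shown, and "the series" means these compounds.

Measured compounds in an ADME assay on A549 cells (Homo sapiens) for cytotoxicity, read by MTT assay, with a stated time of 48 h; on this read-out higher numbers stand for weaker inhibition and lower numbers for stronger inhibition:
- compound 1 `CC(=O)N1N=C(c2cc3ccccc3nc2C)CC1/C=C/c1ccccc1` gives 93.3 ug/mL
- compound 2 `COc1ccc(C2CC(c3cc4ccccc4nc3C)=NN2C(C)=O)cc1` gives 116 ug/mL

Among the measured compounds shown here, compound 2 is one of two measured compounds, and its number lies within the scatter of compound 1; the only measured step, a 1.2-fold higher number from compound 1 to compound 2 (0.09 log units; within the scatter), replaces the whole group on the saturated ring carbon and leaves the read-out essentially unchanged.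

The next compound, compound 3 `COc1ccc(C2CC(c3cc4ccccc4nc3C)=NN2C(C)=O)cc1OC`, differs from compound 2 by methoxy in place of hydrogen on an aromatic carbon. For the measured compounds named here, no measured step touches the aromatic ring of compound 2, so nothing in the data bears directly on this change. Going by the values given here, the one step in hand, a 1.2-fold higher number from compound 1 to compound 2 (0.09 log units; within the scatter), shows that a much larger exchange at the neighbouring position of the shared core stayed within the scatter, which gives no ground to expect a shift from a single methoxy. The expected step is therefore a 1.1-fold lower number from compound 2 to compound 3 (0.02 log units; within the scatter), none beyond the scatter, in either direction.

Compound 3 is estimated at 110 ug/mL in this assay, with a range from 55 ug/mL to 220 ug/mL.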

Compound 3, half-maximal inhibitory concentration: > 200 ug/mL
Compound 3: no number, only a limit; the forecaster's own chance of this, stated with the estimate: 10%; middle value at least 1.8-fold (0.25 log units) away from the limit.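

Methoxy in place of hydrogen on an aromatic carbon, ortho to a methoxy group and meta to a large group, is the first change in these notes on this six-membered aromatic ring, and in this assay compound 3 gives > 200 ug/mL, which is a limit of the assay and not a number. The step can be read only as a floor: an at least 1.7-fold higher number from compound 2 to compound 3 (0.23 log units; that floor lies within the scatter). Among the compounds shown here, the earlier step touched only the saturated ring carbon, and this aromatic position now carries the only limit among the values shown: the limit of > 200 ug/mL in this assay, at which 1 of the 3 values shown sits.

On these data alone, whether the real gap between these two compounds lies beyond the usual scatter stays open, as the floor alone does not settle it. Also open, as far as these compounds go, is how other groups on this aromatic carbon would read, such as hydroxy, an amine or a carboxylic acid, and whether a longer chain in place of the added methoxy would give a measured number or another limit.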